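Swapping Bromo for Methyl on the Sulfonyl Aryl

The source may report more compounds than this note shows. Statements on the series, on what has been measured and on what is new or still open speak of the compounds shown alone.

Compound 3 `COc1ccc(-c2cc(=O)c3c(OC)cc(OC)cc3n2S(=O)(=O)c2ccc(Br)cc2)cc1` is the only one of the three measured compounds that gives a number in a functional assay on HepG2 cells (Homo sapiens) for antiproliferative activity, with a stated time of 72 h; a higher number here means that more compound is needed for the effect, a lower number that less compound is needed: compound 3 shows 16300 nM. Compound 1 `COc1ccc(-c2cc(=O)c3c(OC)cc(OC)cc3n2S(=O)(=O)c2cccc([N+](=O)[O-])c2)cc1` reaches only the limit of > 39600 nM in this assay. Compound 2 `COc1ccc(-c2cc(=O)c3c(OC)cc(OC)cc3n2S(=O)(=O)c2cc(Cl)cc(Cl)c2O)cc1` likewise reaches only the limit of > 37900 nM. Going by the values given here, the steps of an at least 2.4-fold lower number from compound 1 to compound 3 (0.38 log units; beyond the scatter) and an at least 2.3-fold lower number from compound 2 to compound 3 (0.36 log units; beyond the scatter) show that the 4-bromophenyl group on the sulfonyl sulfur gives the lowest number so far. Compound 4 `COc1ccc(-c2cc(=O)c3c(OC)cc(OC)cc3n2S(=O)(=O)c2ccc(C)cc2)cc1` differs from compound 3 by methyl in place of bromo on an aromatic carbon, on an aromatic carbon para to a large group. Among the compounds with values here, no measured step covers this change. A step near the scatter, a 1.5-fold higher number from compound 3 to compound 4 (0.19 log units; within the scatter), is expected, perhaps slightly upward. Compound 4 is therefore estimated at 25000 nM, between 10000 nM and 60000 nM.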

Compound 4, half-maximal effective concentration: > 44800 nM
Compound 4 gave a limit, no number; the forecaster's own chance of this, stated with the estimate: 30%; middle value at least 1.7-fold (0.25 log units) from the limit.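

At this position, para to a large group, bromo and methyl are not interchangeable, even though each is a single heavy atom: methyl in place of bromo gives an at least 2.7-fold higher number from compound 3 to compound 4 (0.43 log units; beyond the scatter). Going by these compounds alone, compound 3 therefore remains the only one of the four compounds with a number rather than a limit, and the steps joining compound 4 to compound 1 or compound 2 cannot be read. Compound 4 itself gives only a limit: the limit of > 44800 nM in this assay, at which 1 of the 4 values shown sits.

On these data alone, whether an amine or a carboxylic acid at this place would give a lower number than compound 3 stays open. The compounds shown also do not tell what separates bromo from methyl here.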